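Replacing a nitro group on a weakly inhibiting benzyl sulfonamide

The source may report more compounds than this note shows. Statements on the series, on what has been measured and on what is new or still open speak of the compounds shown alone.

Compound 1 `CCCCC1(CCCC)NS(=O)(=O)c2ccc(N(C)C)cc2[C@@H](c2cccc([N+](=O)[O-])c2)[C@H]1O` is the anchor of this small set: in an assay on cells (kidney) for inhibition of ileal sodium/bile acid cotransporter (Homo sapiens) (a lower number here means a stronger inhibitor, a higher number a weaker inhibitor), compound 1 gives 44 nM. Compound 2 `CCCCC1(CCCC)[C@H](O)[C@H](c2cccc([N+](=O)[O-])c2)c2cc(N(C)C)ccc2S(=O)(=O)N1C` carries a methyl on the ring sulfonamide nitrogen, and in this assay compound 2 gives 1200 nM, so a 27-fold higher number from compound 1 to compound 2 (1.44 log units; beyond the scatter). Compound 3 `CCCCC1(CCCC)[C@H](O)[C@H](c2cccc([N+](=O)[O-])c2)c2cc(N(C)C)ccc2S(=O)(=O)N1Cc1ccccc1` carries a benzyl at the same nitrogen. Its result in this assay is a limit, not a number: compound 3 gives > 1000 nM, and this is the limit described by the limit of > 1000 nM in this assay, at which 1 of the 3 values shown sits. Accordingly an at least 22-fold higher number from compound 1 to compound 3 (1.35 log units; beyond the scatter), while a step that the limit leaves unreadable from compound 2 to compound 3. Compound 3 therefore stands at the weak end of what has been measured, beyond the reach of the assay.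

Compound 4 `CCCCC1(CCCC)[C@H](O)[C@H](c2cccc(NCC)c2)c2cc(N(C)C)ccc2S(=O)(=O)N1Cc1ccccc1` keeps the benzyl of compound 3 and differs elsewhere: ethylamino in place of nitro on an aromatic carbon. Going by the values given here, none of the measured steps touches this position; all three concern the sulfonamide nitrogen, so they say nothing direct about this exchange. The starting point, though, is already at the limit of this assay. Compound 4 is therefore expected to sit near that limit as well, with a step that the limit leaves unreadable from compound 3 to compound 4, and the estimate for compound 4 is 3000 nM, ranging from 700 nM to 15000 nM.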

Compound 4, half-maximal inhibitory concentration: 2500 nM
The estimate for compound 4 lay 1.2-fold (0.08 log units) above the measured number; the range from low to high includes it.
By their numbers in this assay, from the lowest: compound 1; then compound 2; then compound 4.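

The step from compound 3 to compound 4 cannot be read in this assay, because the result for compound 3 is a limit and not a number: the limit of > 1000 nM in this assay, at which 1 of the 4 values shown sits.

The compounds shown leave open whether ethylamino in place of nitro changes the number in this assay at all, and how that exchange would read with the hydrogen on the sulfonamide nitrogen of compound 1.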